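This account rests on a few compounds, and the source may have more. Where it says the series, first, only, none or still open, it means among the compounds named here.

Two related compounds have been tested in a functional assay on HeLa cells (Homo sapiens) for cytotoxicity, read by cell counting, with a stated time of 48 h; on this read-out lower numbers stand for an effect already at smaller amounts and higher numbers for an effect only at larger amounts of compound. Compound 1 `CCCCCCCC/C=C/CCCCCCCC(=O)O[C@H]1[C@H](O)[C@H](n2ccc(N)nc2=O)O[C@@H]1CO` gives 0.05 ug/mL in this assay, and compound 2 `CCCCCCCCCC(=O)OC[C@H]1O[C@@H](n2ccc(N)nc2=O)[C@@H](O)[C@@H]1O` gives 0.1 ug/mL in this assay; the gap between these two numbers lies within the usual scatter, so the two cannot be told apart on this read-out. Compound 3 `CCCCCCCCCCCCCCCC(=O)O[C@H]1[C@H](O)[C@H](n2ccc(N)nc2=O)O[C@@H]1CO` differs from compound 1 by a group of 8 heavy atoms (8 carbon; no ring) in place of a group of 10 heavy atoms (10 carbon; no ring), on a saturated chain carbon, seven bonds along the chain from a carbonyl carbon. Among the compounds with values here, no measured pair shows such a change, so the step of a 1.6-fold higher number from compound 1 to compound 3 (0.20 log units; within the scatter) is expected to stay within the scatter in either direction. Compound 3 is therefore expected to give about 0.08 ug/mL in this assay, in the range from 0.03 ug/mL to 0.3 ug/mL.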

Compound 3, concentration for half-maximal effect: 0.24 ug/mL
Estimate against measurement, compound 3: 3.0-fold (0.48 log units) below, and the stated range covers the measured number.
By their numbers in this assay, from the lowest: compounds 1 and 2 (each within the scatter of the next); then compound 3.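

At this place, on a saturated chain carbon, seven bonds along the chain from a carbonyl carbon, the group present matters in this assay: octyl in place of the group of 10 heavy atoms with its double bond gives a 4.8-fold higher number from compound 1 to compound 3 (0.68 log units; beyond the scatter). This change shortens the chain and removes the double bond at once, so the step cannot be assigned to either alone. No measurement here offers an explanation for the step. A decyl group at this place would separate those two changes, and a chain ending in an amine would show whether this position accepts anything other than plain carbon.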